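A few compounds are considered here, and "the series" means these few. Any claim that something is new, unique, unknown or untested is made for them only; others in the source may bear on it.

Two compounds of the series have numbers in a functional assay on 786-0 cells (Homo sapiens) for inhibition, read by sulforhodamine B assay, with a stated time of 48 h; on this read-out lower numbers stand for stronger inhibition of growth and higher numbers for weaker inhibition of growth:

compound 1, `COc1cc(-c2cc(/C=C/C(=O)c3ccc(N)cc3)[nH]n2)cc(OC)c1OC`: 6490 nM
compound 2, `COc1ccc(C(=O)/C=C/c2cc(-c3cc(OC)c(OC)c(OC)c3)n[nH]2)cc1OC`: 2860 nM

Compound 2 stands lowest of the two numbers; its nearest neighbour is compound 1, and the gap between them, a 2.3-fold lower number from compound 1 to compound 2 (0.36 log units; beyond the scatter), lies beyond the scatter. Among the compounds with values here, that step exchanges the aryl group on the carbonyl carbon and is the only measured step in the set.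

Compound 3, `COc1ccc(C(=O)/C=C/c2cc(-c3cc(OC)c(OC)c(OC)c3)n[nH]2)cc1`, is not yet measured. It differs from compound 2 in one place: hydrogen in place of methoxy on an aromatic carbon. Read one bond further out, the change is 3,4-dimethoxyphenyl to 4-methoxyphenyl, so it again alters the aryl group on the carbonyl carbon, the region moved by a 2.3-fold lower number from compound 1 to compound 2 (0.36 log units; beyond the scatter). Within the data shown here, that measured step was modest, and no measured pair shows the loss of a single methoxy from this ring, so no direction can be read from the data with confidence. The expectation for compound 3 is therefore a small move, a 1.4-fold higher number from compound 2 to compound 3 (0.15 log units; within the scatter), toward a somewhat higher number than compound 2, within or near the scatter. Compound 3 is estimated at 4000 nM, with a range of 1500 nM to 12000 nM.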

Compound 3, concentration for total growth inhibition: 4130 nM
Beside the measured number, compound 3's estimate is 1.0-fold (0.01 log units) below it, within the range that was stated.
By their numbers in this assay, from the lowest: compounds 2, 3 and 1 (each within the scatter of the next, the first and the last beyond it).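

In this assay, within the data shown here, cutting the 3,4-dimethoxyphenyl group back to 4-methoxyphenyl gives the first reading for the loss of a single methoxy from this ring: a 1.4-fold higher number from compound 2 to compound 3 (0.16 log units; within the scatter). At this aromatic carbon, ortho to a methoxy group, the read-out therefore does not separate hydrogen from methoxy. The second new step, a 1.6-fold lower number from compound 1 to compound 3 (0.20 log units; within the scatter), also stays within the scatter, so 4-methoxyphenyl and 4-aminophenyl are not separated either, whereas the wider exchange of 4-aminophenyl for 3,4-dimethoxyphenyl, a 2.3-fold lower number from compound 1 to compound 2 (0.36 log units; beyond the scatter), lies beyond it; no data bearing on the reason for these numbers are at hand.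

From the compounds shown here alone, whether a hydroxyl, a fluorine or a longer alkoxy chain at this carbon would move the number beyond the scatter remains open. Also open, going by these compounds, is how far the number would shift on an unsubstituted phenyl on the carbonyl carbon, or with a carboxylic acid or a dimethylamino group in place of the remaining methoxy.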